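Working notes: lengthening the octyl chain of compound 2

This account rests on a few compounds, and the source may have more. Where it says the series, first, only, none or still open, it means among the compounds named here.

In a functional assay on DU-145 cells (Homo sapiens) for inhibition, read by MTT assay, with stated times of 18 h and 4 h (a lower number here means a stronger inhibitor, a higher number a weaker inhibitor), compound 1 `CCCCCCCCOP(=O)(O)OCCSC(=S)N1CCCC1` gives 47100 nM. Compound 2 `CCCCCCCCOP(=O)(O)OCCSC(=S)N1CCCCC1` reaches only a limit of the assay, > 100000 nM. Compound 3 `CCCCCCCCCCCCCCCCOP(=O)(O)OCCSC(=S)N1CCCCC1` differs from compound 2 by octyl in place of hydrogen on a saturated chain carbon, eight bonds along the chain from an oxygen on an unsaturated carbon. Among the measured compounds shown here, the one measured step, an at least 2.1-fold higher number from compound 1 to compound 2 (0.32 log units; beyond the scatter), sits at the thiocarbonyl carbon, not on the chain, so it gives no direct size for this change. A move beyond the scatter towards a stronger inhibitor is nevertheless expected, estimated as an at least 5.0-fold lower number from compound 2 to compound 3 (0.69 log units; beyond the scatter), with low confidence. Compound 3 is expected at 20000 nM, within an estimated range of 5000 nM to 80000 nM.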

Compound 3, half-maximal inhibitory concentration: 14700 nM
Estimate against measurement, compound 3: 1.4-fold (0.13 log units) above; the measured number falls inside the stated range.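

In this assay, among the compounds shown here, this chain position now has a measured effect: octyl in place of hydrogen gives an at least 6.8-fold lower number from compound 2 to compound 3 (0.83 log units; beyond the scatter), whereas the only earlier step lay at the thiocarbonyl carbon. With the piperidin-1-yl group unchanged, compound 3 carries a number rather than a limit. The true size of the step remains open-ended because compound 2 stands at a limit of the assay: the limit of > 100000 nM in this assay, at which 1 of the 3 values shown sits.

Open questions are how a dodecyl or an octadecyl chain would compare at this position and whether the same lengthening would carry over to the pyrrolidin-1-yl group of compound 1.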